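One Carbamoyl-to-Trifluoromethyl Swap, Tried on a Second Core

The source may report more compounds than this note shows. Statements on the series, on what has been measured and on what is new or still open speak of the compounds shown alone.

Of the compounds shown here, three sharing one acid-bearing core have been tested in an assay on isolated protein for inhibition of 2-Hydroxyacid oxidase 2 (Homo sapiens), tested at 10 uM; on this read-out lower numbers stand for a weaker effect and higher numbers for a stronger effect at the one concentration tested. Compound 3 `Cc1n[nH]c(C(=O)O)c1Cc1ccc(C(N)=O)cc1` carries a carbamoyl on its aromatic ring, and in this assay compound 3 gives 8%. Compound 1 `Cc1n[nH]c(C(=O)O)c1Cc1ccc(C(F)(F)F)cc1` differs from it by trifluoromethyl in place of carbamoyl on an aromatic carbon, and in this assay compound 1 gives 12%. That exchange made a number 4 percentage points higher from compound 3 to compound 1 (within the scatter), so on this core the two groups behave alike within the usual scatter.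

Compound 2 `Cc1n[nH]c(C(=O)O)c1Cc1cccc(-c2ccc(C(N)=O)cc2)c1` is built on a larger core, and the difference between its core and that of compound 3 is not broken down here. In this assay compound 2 gives 60%, the highest of the three numbers, and its gaps to compound 1 and to compound 3 both lie beyond the scatter.

Compound 4 `Cc1n[nH]c(C(=O)O)c1Cc1cccc(-c2ccc(C(F)(F)F)cc2)c1` has not yet been measured. It differs from compound 2 by trifluoromethyl in place of carbamoyl on an aromatic carbon, the same kind of change that turned compound 3 into compound 1, at the same sort of place. For compound 4 the step in this assay is expected to be about a number 5 percentage points lower from compound 2 to compound 4 (within the scatter), because the same change earlier produced a number 4 percentage points higher from compound 3 to compound 1 (within the scatter) on the smaller core. On that basis compound 4 is estimated to give 55% in this assay, with a plausible range from 25% to 80%.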

Compound 4, a percentage reported as inhibition, at one concentration (the size of the read-out at that concentration, not a potency): 30%
Compound 4: the middle estimate sits 25 percentage points above what was measured; the measured number falls inside the stated range.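

On the larger core, trifluoromethyl in place of carbamoyl gave a number 30 percentage points lower from compound 2 to compound 4 (beyond the scatter) in this assay, so the near-silent result on the smaller core did not carry over: the same change on two cores in this assay, a number 4 percentage points higher (within the scatter) from compound 3 to compound 1 and a number 30 percentage points lower (beyond the scatter) from compound 2 to compound 4, 34 percentage points apart, beyond the scatter of two such steps

For these two cores, then, the outcome of this exchange depended on the core that carried it, and a step read on one core did not predict the step on the other. Going by these compounds alone, this does not show why the two steps differ or whether either is typical of the series, since each core offers only one pair, read at one concentration, and no measurement here separates the contribution of the carbamoyl itself from that of the surrounding core.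

The compounds shown leave open how other groups on the same aromatic carbon of the larger core would read, such as a nitrile, a sulfonamide or a primary amine, and so which part of the carbamoyl this step follows. They also leave open whether compound 2 and compound 4 would keep their order across a range of concentrations, and whether a third core would side with the smaller or the larger one.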